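The compounds below may be only part of what the source reports. "The series", "measured", "known", "first", "only" and "open" are said of these compounds alone.

- compound 1 `CN(C)C(=O)c1nc([C@@H](O)[C@H](O)[C@H](O)CO)c[nH]1`: 1740 ng.h/mL
- compound 2 `Cc1nc(-c2nc([C@@H](O)[C@H](O)[C@H](O)CO)c[nH]2)cs1`: 1970 ng.h/mL

Among the measured compounds shown here, in an ADME assay on the whole organism (plasma, strain 129/SvEvBrd x C57BL/6) for pharmacokinetics, with Mus musculus as the target, at a dose of 10 mg/kg by the oral route (a lower number here means less compound in the circulation, a higher number more compound in the circulation at the dose given), compound 2 gives 1970 ng.h/mL and sits within the scatter of compound 1, the only other measured compound, at 1740 ng.h/mL. Compound 3 `OC[C@@H](O)[C@@H](O)[C@H](O)c1c[nH]c(-c2cscn2)n1` follows from compound 2 by hydrogen in place of methyl on an aromatic carbon, next to the ring nitrogen and next to the ring sulfur.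

For the measured compounds named here, only one measured step bears on this, and only indirectly: a 1.1-fold higher number from compound 1 to compound 2 (0.05 log units; within the scatter), with 2-methyl-1,3-thiazol-4-yl in place of dimethylcarbamoyl. That exchange of a whole group left the number within the scatter. Going by the values given here, no measured step isolates the methyl, so the basis is thin. No step beyond the scatter is expected in this assay, and no direction is favoured. The expected move is a 1.1-fold lower number from compound 2 to compound 3 (0.04 log units; within the scatter). For compound 3 the estimated value is 1800 ng.h/mL, with an expected range of 800 ng.h/mL to 4000 ng.h/mL.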

Compound 3, area under the concentration-time curve: 1570 ng.h/mL
Compound 3: middle estimate off by 1.1-fold (0.06 log units), on the high side, within the range that was stated.
By their numbers in this assay, from the lowest: compounds 3, 1 and 2 (each within the scatter of the next).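

In this assay, among the compounds shown here, hydrogen in place of methyl on this aromatic carbon, next to the ring nitrogen and next to the ring sulfur, gives a 1.3-fold lower number from compound 2 to compound 3 (0.10 log units; within the scatter) and is the first measured step to isolate the methyl, which leaves the number within the scatter. The 1,3-thiazol-4-yl group without the methyl also stays level with the dimethylcarbamoyl group, with a 1.1-fold lower number from compound 1 to compound 3 (0.04 log units; within the scatter), so all three compounds now sit within the scatter of each other. No measurement at hand bears on why these numbers stay level.

On these data alone, how an amine, a hydroxyl or a longer chain such as propyl on this same carbon would read stays open. Also open, as far as these compounds go, is whether any group in place of the 1,3-thiazol-4-yl, such as a carboxylic acid, would move the number beyond the scatter.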